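Exchanging the Carbonyl Partner of Compound 1

The source may hold more compounds than are shown below. What is called first, only, known or untested is meant among the compounds shown, and "the series" means these compounds.

Compound 1 `CCCN(CC1CCOC1)C(=O)c1cc(OC)c2oc(NCc3cccc(Cl)c3)nc2c1` gives 12 nM in an assay on isolated protein for inhibition of thyroid hormone receptor beta (Homo sapiens), read by fluorescence, with a stated time of 30 min (on this read-out lower numbers stand for stronger inhibition and higher numbers for weaker inhibition), the lowest of the three measured numbers. Compound 2 `CCCN(CC1CCOC1)C(=O)c1cc(CC)c2oc(NCc3cccc(Cl)c3)nc2c1` gives 104 nM and compound 3 `CCCc1cc(C(=O)N(CCC)CC2CCOC2)cc2nc(NCc3cccc(Cl)c3)oc12` gives 957 nM. The steps of an 8.7-fold higher number from compound 1 to compound 2 (0.94 log units; beyond the scatter) and an 80-fold higher number from compound 1 to compound 3 (1.90 log units; beyond the scatter) both change only the substituent on the aromatic ring, and both weaken inhibition beyond the scatter. Compound 4 `COc1cc(C(=O)N2CC(C)C(O)CC2C2CC2)cc2nc(NCc3cccc(Cl)c3)oc12` alters a different part of the shared core: 2-cyclopropyl-4-hydroxy-5-methylpiperidin-1-yl in place of ((oxolan-3-yl)methyl)(propyl)amino on a carbonyl carbon. Among the measured compounds shown here, no measured step touches the carbonyl carbon, so the earlier steps offer no direct guide. The whole group there is exchanged, a larger change than any measured one, so a shift beyond the scatter is plausible. The expected step is a 2.9-fold higher number from compound 1 to compound 4 (0.46 log units; beyond the scatter), a modest weakening. Compound 4 is expected to give about 35 nM, within 8 nM to 150 nM.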

Compound 4, half-maximal inhibitory concentration: 8 nM
Estimate against measurement, compound 4: 4.4-fold (0.64 log units) above, within the range that was stated.
By their numbers in this assay, from the lowest: compounds 4 and 1 (each within the scatter of the next); then compound 2; then compound 3.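

On the carbonyl carbon, the whole group can be exchanged with no readable change in this assay, as a 1.5-fold lower number from compound 1 to compound 4 (0.18 log units; within the scatter) shows. The earlier steps shown here changed only the aromatic substituent and all lay beyond the scatter, whereas this first change at the carbonyl carbon stays within it, even with an added hydrogen-bond donor and a second ring. No measurement shown gives a reason for this result.

From the compounds shown here alone, the hydroxy, methyl and cyclopropyl groups enter together, so their separate contributions remain open, as does the outcome of placing an amine or a carboxylic acid where the hydroxy stands.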